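This account rests on a few compounds, and the source may have more. Where it says the series, first, only, none or still open, it means among the compounds named here.

Compound 1 `O=c1c(CSC(=S)N2CCOCC2)coc2cc(Cl)ccc12` was examined in a functional assay on HEp-2 cells (Homo sapiens) for antiproliferative activity, read by MTT assay, with a stated time of 72 h (a lower number here means a stronger inhibitor, a higher number a weaker inhibitor), where compound 1 gives 900 nM. Among the three measured compounds it stands second highest. For the measured compounds named here, its nearest neighbour is compound 2 `O=c1c(CSC(=S)N2CCCCC2)coc2cc(Cl)ccc12`, which in this assay gives 280 nM; the one change, piperidin-1-yl in place of morpholin-4-yl on a thiocarbonyl carbon, brings a 3.2-fold lower number from compound 1 to compound 2 (0.51 log units; beyond the scatter). Going by the values given here, the furthest is compound 3 `O=c1cc(CSC(=S)N2CCOCC2)oc2cc(Cl)ccc12`, which in this assay gives 20600 nM; no single-place step joins compound 1 to compound 3, so the two values are simply set side by side, and compound 3 sits far to the weaker side.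

Compound 4 `Cc1ccc2c(=O)c(CSC(=S)N3CCOCC3)coc2c1` differs from compound 1 by methyl in place of chloro on an aromatic carbon. Among the compounds with values here, none of the measured steps touches this carbon or exchanges chloro for methyl anywhere; the only measured step, the one from compound 1 to compound 2, concerns the ring on the thiocarbonyl carbon. There is therefore no measured basis for expecting a shift beyond the scatter, and the expected step for compound 4 is a 1.2-fold higher number from compound 1 to compound 4 (0.09 log units; within the scatter), with a wide allowance in either direction. Compound 4 is thus estimated at 1100 nM in this assay, within a range of 350 nM to 3500 nM.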

Compound 4, half-maximal inhibitory concentration: 4000 nM
Compound 4: middle estimate off by 3.6-fold (0.56 log units), on the low side; the whole stated range lies below it.
By their numbers in this assay, from the lowest: compound 2; then compound 1; then compound 4; then compound 3.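

In this assay the exchange of chloro for methyl on this aromatic carbon brings a 4.4-fold higher number from compound 1 to compound 4 (0.65 log units; beyond the scatter) and so gives the first measured sign that the group at this place of the core bears on the reading, with methyl on the weaker side of chloro in the morpholin-4-yl series. The earlier step concerned only the other end of the molecule, where piperidin-1-yl in place of morpholin-4-yl on a thiocarbonyl carbon brought a 3.2-fold lower number from compound 1 to compound 2 (0.51 log units; beyond the scatter) in the opposite direction, so both ends of compound 1 now have a measured change beyond the scatter. No measured information is available to explain the difference between chloro and methyl at this carbon.

The compounds shown leave open what hydrogen, fluoro, bromo or methoxy on this carbon would give, so chloro and methyl remain only two points at this position. They also leave open whether the step from chloro to methyl keeps its size and direction when piperidin-1-yl replaces morpholin-4-yl on the thiocarbonyl carbon.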